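Furanyl purine nucleosides: antiproliferative limits and an expected analogue

A few compounds are considered here, and "the series" means these few. Any claim that something is new, unique, unknown or untested is made for them only; others in the source may bear on it.

Compound 1 `Nc1nc2c(c(-c3ccco3)cn2[C@@H]2O[C@H](CO)[C@@H](O)[C@H]2O)c(=O)[nH]1`, in a functional assay on HL-60 cells (Homo sapiens) for antiproliferative activity, read by XTT assay, with a stated time of 72 h (on this read-out lower numbers stand for stronger inhibition and higher numbers for weaker inhibition), compound 1 gives a limit, > 20000 nM.
Compound 2 `COc1nc(N)nc2c1c(-c1ccoc1)cn2[C@@H]1O[C@H](CO)[C@@H](O)[C@H]1O`, in this assay compound 2 gives a limit, > 20000 nM.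
Compound 3 `Nc1nc2c(c(-c3ccoc3)cn2[C@@H]2O[C@H](CO)[C@@H](O)[C@H]2O)c(=O)[nH]1`, in this assay compound 3 gives a limit, > 15000 nM.

Every value is a limit rather than a number. The change from compound 3 to compound 1 furan-2-yl in place of furan-3-yl on an aromatic carbon gives a step that the two limits leave unreadable from compound 3 to compound 1; the two limits leave its size unreadable, as the limit of > 15000 nM in this assay, at which 1 of the 3 values shown sits, and the limit of > 20000 nM in this assay, at which 2 of the 3 values shown sit, show. Compound 4 `COc1nc(N)nc2c1c(-c1ccco1)cn2[C@@H]1O[C@H](CO)[C@@H](O)[C@H]1O`, not yet measured, carries the same kind of change on compound 2 (furan-2-yl in place of furan-3-yl on an aromatic carbon); the difference between the two cores of compound 2 and compound 3 is not broken down here. Since the measured step rests only on limits, the step from compound 2 to compound 4 is expected to be a step that the limit leaves unreadable from compound 2 to compound 4. In this assay compound 4 is estimated at 30000 nM, between 15000 nM and 100000 nM, most likely again a limit.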

Compound 4, half-maximal inhibitory concentration: > 20000 nM
Compound 4 ended at the assay's limit (the forecaster's own chance of this, stated with the estimate: 85%); the middle value does not contradict the limit.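

Compound 2 and compound 4 both end at limits in this assay, so no step can be read between them. The compounds shown leave open whether furan-2-yl and furan-3-yl differ at all in this assay.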